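This account rests on a few compounds, and the source may have more. Where it says the series, first, only, none or still open, it means among the compounds named here.

Working notes on the series in a functional assay on HL-60 cells (Homo sapiens) for antiproliferative activity, read by MTT assay, with a stated time of 48 h; a lower number here means a stronger inhibitor, a higher number a weaker inhibitor. Compound 1 `Cn1c(N)c(-c2nc3ccccc3[nH]2)c2nc(C#N)c(C#N)nc21` reads > 50000 nM, which is a limit of the assay and not a number. Compound 2 `CCN(CC)CCn1c(N)c(-c2nc3ccccc3[nH]2)c2nc(C#N)c(C#N)nc21` gives 1880 nM, and compound 3 `N#Cc1nc2c(-c3nc4ccccc4[nH]3)c(N)n(CCN3CCCC3)c2nc1C#N` gives 4760 nM. Compound 3 therefore holds the higher of the two actual numbers, with compound 2 as its nearest neighbour.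

The open case is compound 4 `CN1CCN(CCn2c(N)c(-c3nc4ccccc4[nH]3)c3nc(C#N)c(C#N)nc32)CC1`, which carries 4-methylpiperazin-1-yl in place of pyrrolidin-1-yl on a saturated chain carbon, two bonds along the chain from an aromatic nitrogen.

Three measured steps are relevant. Two are large, an at least 26-fold lower number from compound 1 to compound 2 (1.42 log units; beyond the scatter) and an at least 10-fold lower number from compound 1 to compound 3 (1.02 log units; beyond the scatter), but both start from compound 1 and rest on (the limit of > 50000 nM in this assay, at which 1 of the 3 values shown sits). They show what extending the chain did, not what exchanging its end group does. Within the data shown here, the closest precedent is a 2.5-fold higher number from compound 2 to compound 3 (0.40 log units; beyond the scatter), a modest step and the only measured exchange at this place. One exchange gives no firm direction for a new end group. In this assay, no step beyond the scatter is therefore the central expectation, although a modest step either way remains possible. The expected step is a 1.2-fold lower number from compound 3 to compound 4 (0.08 log units; within the scatter). The estimated value for compound 4 is 4000 nM, with an expected range from 1500 nM to 12000 nM.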

Compound 4, half-maximal inhibitory concentration: 4300 nM
Compound 4: middle estimate off by 1.1-fold (0.03 log units), on the low side; the measured number falls inside the stated range.
By their numbers in this assay, from the lowest: compound 2; then compounds 4 and 3 (each within the scatter of the next). At a limit, above all of these: compound 1.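

In this assay the second exchange of the end group at this place gives a 1.1-fold lower number from compound 3 to compound 4 (0.04 log units; within the scatter), so 4-methylpiperazin-1-yl and pyrrolidin-1-yl cannot be told apart on the saturated chain carbon, despite the change from a five-membered ring to a six-membered ring with a second ring nitrogen. Compound 2 now stands apart from both ring-bearing compounds, with a 2.3-fold higher number from compound 2 to compound 4 (0.36 log units; beyond the scatter) alongside a 2.5-fold higher number from compound 2 to compound 3 (0.40 log units; beyond the scatter), so among these three compounds the diethylamino end group gives the lowest number, by modest steps. The large step from the short chain also holds for this third end group, as an at least 11-fold lower number from compound 1 to compound 4 (1.06 log units; beyond the scatter), but compound 1 carries a limit and not a number, so the true size of that step stays unknown: the limit of > 50000 nM in this assay, at which 1 of the 4 values shown sits.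

Compound 4 differs from compound 3 in ring size, ring nitrogen and methyl group together, and these remain unseparated; a piperazin-1-yl or morpholin-4-yl end group on the same chain would help to separate them. On these data alone, how a propyl chain carrying the same end groups would read in this assay also remains open.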